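This account rests on a few compounds, and the source may have more. Where it says the series, first, only, none or still open, it means among the compounds named here.

Measured so far:
- compound 1 `CC/C=C\[C@H](C)[C@H](OC(N)=O)[C@@H](C)[C@H](O)[C@@H](C)C/C(C)=C\[C@H](C)[C@@H](O)[C@@H](C)/C=C\[C@@H](O)C[C@H](O)[C@H](C)CO`: 10000 nM
- compound 2 `CC/C=C\[C@H](C)[C@H](OC(N)=O)[C@@H](C)[C@H](O)[C@@H](C)C/C(C)=C\[C@H](C)[C@@H](O)[C@@H](C)/C=C\[C@@H](O)C[C@H]1CCC(=O)O1`: 730 nM
- compound 3 `CC/C=C\[C@H](C)[C@H](OC(N)=O)[C@@H](C)[C@H](O)[C@@H](C)C/C(C)=C\[C@H](C)[C@@H](O)[C@@H](C)/C=C\[C@@H](O)C[C@@H]1OC(=O)NC[C@H]1C`: 10000 nM

Within the data shown here, in a functional assay on NCI/ADR-RES cells (Homo sapiens) for antiproliferative activity (on this read-out lower numbers stand for stronger inhibition of growth and higher numbers for weaker inhibition of growth), compound 3 stands level with compound 1, the two together giving the highest numbers of the three; its only separation is from compound 2, a 14-fold higher number from compound 2 to compound 3 (1.14 log units; beyond the scatter).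

Compound 4 `CC/C=C\[C@H](C)[C@H](OC(N)=O)[C@@H](C)[C@H](O)[C@@H](C)C/C(C)=C\[C@H](C)[C@@H](O)[C@@H](C)/C=C\[C@@H](O)C[C@@H]1OC(=O)[C@H](C)[C@@H](O)[C@H]1C` is the next step from compound 3. The change is a group of 10 heavy atoms (7 carbon, 3 oxygen; one six-membered non-aromatic ring with 1 hetero atom) in place of a group of 8 heavy atoms (5 carbon, 1 nitrogen, 2 oxygen; one six-membered non-aromatic ring with 2 hetero atoms), on a saturated chain carbon, two bonds along the chain from a double-bonded chain carbon and an oxygen on a saturated carbon.

Among the measured compounds shown here, two measured steps bear on it. Closing the open chain of compound 1 into a five-membered ring with one hetero atom gave a 14-fold lower number from compound 1 to compound 2 (1.14 log units; beyond the scatter), while the six-membered ring with two hetero atoms of compound 3 brought none of that gain, no change at the digits printed from compound 1 to compound 3 (within the scatter). For the measured compounds named here, compound 4 returns to a ring with a single hetero atom, here six-membered, so a step in the direction of compound 2 is expected in this assay, though no measured pair shows this exact ring. The expected step is a 33-fold lower number from compound 3 to compound 4 (1.52 log units; beyond the scatter).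

Compound 4 is therefore estimated at 300 nM, with a range of 40 nM to 2500 nM.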

Compound 4, concentration for 50% growth inhibition: 190 nM
The estimate for compound 4 lay 1.6-fold (0.20 log units) above the measured number, within the range that was stated.
By their numbers in this assay, from the lowest: compound 4; then compound 2; then compounds 1 and 3 (each within the scatter of the next).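

In this assay, a six-membered ring at this saturated chain carbon proves compatible with a large gain, as a 53-fold lower number from compound 3 to compound 4 (1.72 log units; beyond the scatter) and a 53-fold lower number from compound 1 to compound 4 (1.72 log units; beyond the scatter) show, whereas the six-membered ring with 2 hetero atoms of compound 3 had brought none. The five-membered ring of compound 2 is also not the best group seen here, given a 3.8-fold lower number from compound 2 to compound 4 (0.58 log units; beyond the scatter), a modest step but beyond the scatter. No supporting data on the origin of these steps are available.

Between compound 3 and compound 4, the ring hetero atoms, the group size and the number of stereocentres all change at once, so the part of the entering group that carries the step remains open. On these data alone, how an open-chain carboxylic acid or an amine at this carbon would read in this assay also remains open.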